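Amide Variation on the Side Chain of Compound 1

This account rests on a few compounds, and the source may have more. Where it says the series, first, only, none or still open, it means among the compounds named here.

Compound 1, `CNC(=O)Cn1nc(N)c2c(C(F)(F)F)cc(-c3ccccc3)nc21`: 12200 nM
Compound 2, `Nc1nn(CC(=O)NCCO)c2nc(-c3ccccc3)cc(C(F)(F)F)c12`: 69500 nM
Compound 3, `Nc1nn(CC(=O)NCc2ccccc2)c2nc(-c3ccccc3)cc(C(F)(F)F)c12`: 17100 nM

Of the compounds shown here, three sharing the core of compound 1 have been tested in a functional assay on HeLa cells (Homo sapiens) for cytotoxicity, read by MTT assay, with a stated time of 24 h; a higher number here means a weaker inhibitor, a lower number a stronger inhibitor. Compound 1 gives the lowest of the three numbers, 12200 nM; compound 3 stands nearest to it, and compound 2 lies furthest away.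

Compound 4, `Nc1nn(CC(=O)N2CCOCC2)c2nc(-c3ccccc3)cc(C(F)(F)F)c12`, has not yet been measured. It differs from compound 1 at the carbonyl carbon whose other neighbours are a saturated chain carbon: morpholin-4-yl in place of methylamino on a carbonyl carbon. The measured steps all alter what is carried by the amide-type nitrogen. Adding a hydroxymethyl there gave a 5.7-fold higher number from compound 1 to compound 2 (0.76 log units; beyond the scatter), adding a phenyl gave a 1.4-fold higher number from compound 1 to compound 3 (0.15 log units; within the scatter), and between those two compounds a 4.1-fold lower number from compound 2 to compound 3 (0.61 log units; beyond the scatter). Every variation of the amide end so far has moved the number upward or left it unchanged, and none of them closed the nitrogen into a ring or removed its hydrogen-bond donor, so the present change is new in kind.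

Compound 4 is therefore expected to give a slightly higher number than compound 1, a step of a 1.6-fold higher number from compound 1 to compound 4 (0.21 log units; within the scatter), close to the edge of the scatter. The estimate for compound 4 is 20000 nM, with a range from 8000 nM to 60000 nM.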

Compound 4, half-maximal inhibitory concentration: 6600 nM
Estimate against measurement, compound 4: 3.0-fold (0.48 log units) above, outside the stated range (below it).
By their numbers in this assay, from the lowest: compounds 4, 1 and 3 (each within the scatter of the next, the first and the last beyond it); then compound 2.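

In this assay, closing the amide nitrogen into morpholin-4-yl removes the amide hydrogen and adds a six-membered ring, yet compound 4 cannot be told apart from compound 1 (a 1.8-fold lower number from compound 1 to compound 4 (0.27 log units; within the scatter)), so this end of the side chain accepts both changes together without a measurable loss. Among the compounds shown here, the same group does separate from the other two amides, with a 2.6-fold lower number from compound 3 to compound 4 (0.41 log units; beyond the scatter) and, the largest step so far, an 11-fold lower number from compound 2 to compound 4 (1.02 log units; beyond the scatter), which places compound 4 with compound 1 at the low end of the series without an order between them. Nothing measured alongside these numbers gives a reason for these steps.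

The compounds shown do not separate the loss of the amide hydrogen from the presence of the ring, since dimethylamino would carry no amide hydrogen and no ring, while piperidin-1-yl would keep the ring without its oxygen. Also open, going by these compounds, is whether a piperazin-1-yl group, with a second ring nitrogen in place of that oxygen, or a carboxylic acid at the end of a longer chain would hold the number at this level.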